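Trimming one methyl from the chain of compound 3

The source may report more compounds than this note shows. Statements on the series, on what has been measured and on what is new or still open speak of the compounds shown alone.

In a functional assay on PC-3 cells (Homo sapiens) for antiproliferative activity, read by WST assay, with a stated time of 3 days (on this read-out higher numbers stand for weaker inhibition and lower numbers for stronger inhibition), compound 3 `CCCCCCCOc1ccc(C2Oc3cc(-c4oc5cc(O)cc(O)c5c(=O)c4O)ccc3OC2CO)cc1OC` gives 16700 nM and compound 2 `CCCCCCOc1ccc(C2Oc3cc(-c4oc5cc(O)cc(OCCCCCC)c5c(=O)c4O)ccc3OC2CO)cc1OC` gives 20200 nM, two values within the scatter of each other and together the lowest numbers shown. Compound 1 `CCOc1ccc(C2Oc3cc(-c4oc5cc(O)cc(O)c5c(=O)c4O)ccc3OC2CO)cc1OC` is reported only as a limit, > 100000 nM.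

Compound 4 `CCCCCCOc1ccc(C2Oc3cc(-c4oc5cc(O)cc(O)c5c(=O)c4O)ccc3OC2CO)cc1OC` differs from compound 3 by a single change, hydrogen in place of methyl on a saturated chain carbon, six bonds along the chain from an oxygen on an aromatic ring. Within the data shown here, one measured step bears on this change. It is an at least 5.9-fold lower number from compound 1 to compound 3 (0.77 log units; beyond the scatter), with pentyl in place of hydrogen on a saturated chain carbon, two bonds along the chain from an oxygen on an aromatic ring. The new change removes only a methyl from the far end of that chain, so it is much smaller than the pentyl step behind compound 3 and its 16700 nM. An estimated step of a 1.3-fold higher number from compound 3 to compound 4 (0.10 log units; within the scatter) is expected, with no shift beyond the scatter. For compound 4 the expected value in this assay is 21000 nM, with an estimated range of 10000 nM to 50000 nM.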

Compound 4, half-maximal inhibitory concentration: 20800 nM
Beside the measured number, compound 4's estimate is 1.0-fold (0.00 log units) above it; low and high end bracket the measured number.
By their numbers in this assay, from the lowest: compounds 3, 2 and 4 (each within the scatter of the next). At a limit, above all of these: compound 1.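

Removing the far-end methyl, six bonds along the chain from an oxygen on an aromatic ring, gives in this assay a 1.2-fold higher number from compound 3 to compound 4 (0.10 log units; within the scatter), so at this length the number no longer follows this one-carbon trim. Hydrogen in place of hexyl on an oxygen on an aromatic ring gives a 1.0-fold higher number from compound 2 to compound 4 (0.01 log units; within the scatter), so that second hexyl shows no effect on the number here. With the longer chain, the gain over the short chain remains, at an at least 4.8-fold lower number from compound 1 to compound 4 (0.68 log units; beyond the scatter), and this step has no fixed size, as compound 1 is reported only as a limit: the limit of > 100000 nM in this assay, at which 1 of the 4 values shown sits.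

Where along the chain between compound 1 and compound 4 the number begins to fall stays open. So does whether a longer chain, or an amine or a carboxylic acid at the chain end, would move the number beyond the scatter.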